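This account rests on a few compounds, and the source may have more. Where it says the series, first, only, none or still open, it means among the compounds named here.

Measured in a functional assay on HCT-116 cells (Homo sapiens) for inhibition, read by colorimetric assay, with a stated time of 3 days; a higher number here means a weaker inhibitor, a lower number a stronger inhibitor:
Compound 1, `O=C(CCCCCCNC(=O)C(O)(O)C(F)(F)F)Nc1ccc(Br)cc1`: 3130 nM.
Compound 2, `Cc1ccc(S(=O)(=O)Nc2ccc(NC(=O)CCCCCCNC(=O)C(O)(O)C(F)(F)F)cc2)cc1`: 17200 nM.
Compound 3, `O=C(CCCCCCNC(=O)C(O)(O)C(F)(F)F)Nc1ccc(-c2ccccc2)cc1`: 4730 nM.

Compound 1 has the lowest number of the three; compound 3 sits within the scatter of it, while compound 2 lies further off, a 5.5-fold higher number from compound 1 to compound 2 (0.74 log units; beyond the scatter). The next compound, compound 4 `O=C(CCCCCCNC(=O)C(O)(O)C(F)(F)F)Nc1nc2ccccc2o1`, differs from compound 1 as follows: 1,3-benzoxazol-2-yl in place of 4-bromophenyl on an amide-type nitrogen. Going by the values given here, none of the measured steps replaces the whole group on the amide-type nitrogen; they only vary the substituent on that aryl ring, a 1.5-fold higher number from compound 1 to compound 3 (0.18 log units; within the scatter) and a 3.6-fold lower number from compound 2 to compound 3 (0.56 log units; beyond the scatter). They show this end accepting one change within the scatter and one modest loss, so a small to modest rise is expected, a 1.4-fold higher number from compound 1 to compound 4 (0.16 log units; within the scatter). Compound 4 is therefore estimated at 4500 nM, with a range of 1500 nM to 14000 nM.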

Compound 4, half-maximal inhibitory concentration: 3450 nM
Estimate against measurement, compound 4: 1.3-fold (0.12 log units) above; the range from low to high includes it.
By their numbers in this assay, from the lowest: compounds 1, 4 and 3 (each within the scatter of the next); then compound 2.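

Replacing the whole 4-bromophenyl on the amide-type nitrogen with 1,3-benzoxazol-2-yl gives a 1.1-fold higher number from compound 1 to compound 4 (0.04 log units; within the scatter) and so shows that this position accepts a change of the aromatic group itself, not only of the substituent on its ring. The entering group adds a five-membered aromatic ring with 2 hetero atoms and 2 hydrogen-bond acceptors, without a step beyond the scatter. No measurement at hand accounts for this result. As far as these compounds go, whether an amine or a carboxylic acid on the 1,3-benzoxazol-2-yl group would shift the number remains open, as does the effect of a longer chain.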